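Swapping the Thioether Arm of Compound 3

The compounds below may be only part of what the source reports. "The series", "measured", "known", "first", "only" and "open" are said of these compounds alone.

Compound 3 `C=C1CC[C@@H]2[C@](C)(CO)[C@H](O)CC[C@@]2(C)[C@@H]1C/C=C1/C(=O)OC[C@H]1OC(=O)CSc1ccc(F)cc1` is tested in a functional assay on PC-3 cells (Homo sapiens) for inhibition, read by MTT assay, with a stated time of 48 h (on this read-out higher numbers stand for weaker inhibition and lower numbers for stronger inhibition), where compound 3 gives 14000 nM. Of the three measured compounds it holds the second highest number. Among the measured compounds shown here, compound 2 `C=C1CC[C@@H]2[C@](C)(CO)[C@H](O)CC[C@@]2(C)[C@@H]1C/C=C1/C(=O)OCC1OC(=O)CSc1ccc(F)cc1` gives 13000 nM; the step of a 1.1-fold higher number from compound 2 to compound 3 (0.03 log units; within the scatter) is the only single-place change measured so far, and it rests solely on (the fact that one of compounds 2 and 3 is drawn with a defined configuration and the other without, at the place where they differ). Compound 1 `C=C1CC[C@@H]2[C@](C)(CO)[C@H](O)CC[C@@]2(C)[C@@H]1CC(Sc1ccc(C)cc1)C1=CCOC1=O` gives 29000 nM, a number that lies beyond the scatter above that of compound 3, yet compound 1 differs from compound 3 in more than one place. Compound 4 `C=C1CC[C@@H]2[C@](C)(CO)[C@H](O)CC[C@@]2(C)[C@@H]1C/C=C1/C(=O)OC[C@H]1OC(=O)CCCSc1ccc([N+](=O)[O-])cc1` arises from compound 3 by 2-((4-nitrophenyl)sulfanyl)ethyl in place of (4-fluorophenyl)sulfanyl on a saturated chain carbon bound to a carbonyl carbon. For the measured compounds named here, no measured step covers such a change, so no shift beyond the scatter is expected. Compound 4 is estimated at 12000 nM, between 4000 nM and 40000 nM, an expected step of a 1.2-fold lower number from compound 3 to compound 4 (0.07 log units; within the scatter).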

Compound 4, half-maximal inhibitory concentration: 17000 nM
The estimate for compound 4 lay 1.4-fold (0.15 log units) below the measured number; the range from low to high includes it.
By their numbers in this assay, from the lowest: compounds 2, 3, 4 and 1 (each within the scatter of the next, the first and the last beyond it).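

In this assay, exchanging (4-fluorophenyl)sulfanyl for 2-((4-nitrophenyl)sulfanyl)ethyl on this saturated chain carbon gives a 1.2-fold higher number from compound 3 to compound 4 (0.08 log units; within the scatter). Among the compounds shown here, this is the first measured change to the arm itself, and it shows that a different arm at this place can leave the number within the scatter. Nothing measured here accounts for this result.

From the compounds shown here alone, the chain and the ring substituent change together, so their separate contributions stay open. Going by these compounds, whether an amine or a carboxylic acid at this place would also leave the number unmoved remains unknown.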